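Swapping Fluoro for Trifluoromethoxy on a Growth Inhibitor

The compounds below may be only part of what the source reports. "The series", "measured", "known", "first", "only" and "open" are said of these compounds alone.

Values measured in a functional assay on DWD cells (Homo sapiens) for inhibition, read by sulforhodamine B assay (a higher number here means a weaker inhibitor of growth, a lower number a stronger inhibitor of growth), are:
- compound 1 `Cc1ccc2[nH]c(-c3ccc(-c4ccc(-c5cccc(Cl)c5)cc4)cc3)nc2c1` gives 2510 nM
- compound 2 `Oc1cccc2[nH]c(-c3ccc(-c4ccc(-c5ccc(OC(F)(F)F)cc5)cc4)cc3)nc12` gives 3100 nM
- compound 3 `Cc1ccc2[nH]c(-c3ccc(-c4ccc(-c5ccc(F)cc5)cc4)cc3)nc2c1` gives 33100 nM

Of these three, compound 3 has the highest number (33100 nM) and is therefore the weakest growth inhibitor, clearly apart from the other two. The next compound, compound 4 `Cc1ccc2[nH]c(-c3ccc(-c4ccc(-c5ccc(OC(F)(F)F)cc5)cc4)cc3)nc2c1`, keeps the core of compound 3 and changes one group: trifluoromethoxy in place of fluoro on an aromatic carbon.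

One measured step changes that same outer group on this core. There is a 13-fold higher number from compound 1 to compound 3 (1.12 log units; beyond the scatter) when 4-fluorophenyl replaces 3-chlorophenyl, a large change. The number here can therefore move far with this group, and 4-fluorophenyl sits at the weak end so far. The 4-(trifluoromethoxy)phenyl group also appears on a differently substituted core in compound 2, which gives 3100 nM in this assay and so points towards a lower number. Going by the values given here, no measured pair tests this swap directly, so the expectation is uncertain. The estimated change is a 7.4-fold lower number from compound 3 to compound 4 (0.87 log units; beyond the scatter) and is expected to be large, towards stronger inhibition. Compound 4 is expected at 4500 nM (estimated range 1500 nM to 15000 nM).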

Compound 4, concentration for 50% growth inhibition: 41100 nM
Estimate against measurement, compound 4: 9.1-fold (0.96 log units) below, and the stated range ends below it.
By their numbers in this assay, from the lowest: compounds 1 and 2 (each within the scatter of the next); then compounds 3 and 4 (each within the scatter of the next).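

In this assay the outer group on this core changes from fluoro to trifluoromethoxy (a 1.2-fold higher number from compound 3 to compound 4 (0.09 log units; within the scatter)), so five heavy atoms in place of one at this spot leave the two compounds indistinguishable. The 4-(trifluoromethoxy)phenyl group therefore does not bring a low number by itself: with this same outer group, 5-methyl-1H-benzimidazol-2-yl in place of 4-hydroxy-1H-benzimidazol-2-yl gives a large shift (a 13-fold higher number from compound 2 to compound 4 (1.12 log units; beyond the scatter)), which shows that the other end of the molecule counts as well. On the methyl-bearing core, the 3-chlorophenyl group of compound 1 now stands apart from both 4-substituted phenyl groups, since the step to 4-(trifluoromethoxy)phenyl (a 16-fold higher number from compound 1 to compound 4 (1.21 log units; beyond the scatter)) is as clear as the earlier step to 4-fluorophenyl (a 13-fold higher number from compound 1 to compound 3 (1.12 log units; beyond the scatter)). Nothing shown here gives a reason for any of these differences.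

Compounds 1, 3 and 4 differ in both the substituent and its place on the outer ring, so the 4-chlorophenyl and 3-fluorophenyl groups would be needed to separate the chlorine from its position. On these data alone, it also remains open whether the hydroxy group on the core of compound 2 would lift a 4-fluorophenyl or 3-chlorophenyl compound in the same way, or whether an amine at that spot would behave like it.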